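This account rests on a few compounds, and the source may have more. Where it says the series, first, only, none or still open, it means among the compounds named here.

Of the compounds shown here, two have been read so far in an ADME assay on microsomes from liver (Mus musculus) for metabolic stability, read by LC-MS, using NADPH, tested at 1 uM; a higher number here means that the compound lasts longer, a lower number that the compound disappears faster. Compound 1 `CC(=O)NC/C=C\CN(C)C[C@H]1O[C@@H](n2cnc3c(N)ncnc32)[C@H](OC(C)=O)[C@@H]1OC(C)=O` gives 0.11 h, a measured number. Compound 2 `CNc1ncnc2c1ncn2[C@@H]1O[C@H](CN(C)C/C=C\CN)[C@@H](O)[C@H]1O` gives > 1.5 h, which is a limit of the assay and not a number. Compound 2 therefore stands at the limit of > 1.5 h in this assay, at which 1 of the 2 values shown sits, and no exact value is available for it.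

Compound 3 `CC(C)Nc1ncnc2c1ncn2[C@@H]1O[C@H](CN(C)C/C=C\CN)[C@@H](O)[C@H]1O` differs from compound 2 in one place: isopropyl in place of methyl on a nitrogen on an aromatic ring. In words, this is isopropyl in place of methyl on a nitrogen on an aromatic ring, or methylamino to isopropylamino. Going by the values given here, no measured pair in this set shows what such a change does, so the size of the step in this assay cannot be read from precedent. With compound 2 at > 1.5 h, a limit, the expectation has only that limit as its starting point. A modest step downward is expected, of a size close to the scatter, and no real change would not be a surprise. The expected change is an at least 1.1-fold lower number from compound 2 to compound 3 (0.06 log units; that floor lies within the scatter). The reading may again come back as a limit. For compound 3 the estimated half-life is 1.3 h, with an expected range from 0.5 h to 2.5 h.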

Compound 3, half-life: > 1.5 h
Compound 3: a limit, no number; the forecaster's own chance of this, stated with the estimate: 45%; middle value at least 1.1-fold (0.06 log units) away from the limit.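

In this assay compound 3 gives > 1.5 h and this is a limit, not a number. Compound 2 gives > 1.5 h and this too is a limit, so no step between compound 2 and compound 3 can be read: the limit of > 1.5 h in this assay, at which 2 of the 3 values shown sit.

The compounds shown leave open whether isopropyl in place of methyl on a nitrogen on an aromatic ring changes the half-life at all.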